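Methylsulfanyl in place of bromo: clearance of compound 4

The source may report more compounds than this note shows. Statements on the series, on what has been measured and on what is new or still open speak of the compounds shown alone.

In an ADME assay on microsomes from liver (Homo sapiens) for metabolic stability, read by LC-MS (on this read-out lower numbers stand for slow clearance and higher numbers for fast clearance), compound 1 (`FC(F)(F)c1nccc(N[C@H]2CC[C@@H](Nc3ccc4ncc(Cl)n4n3)CC2)n1`) gives 9.9 mL.min-1.g-1. Compound 2 (`FC(F)(F)c1nccc(N[C@H]2CC[C@@H](Nc3ccc4nncn4n3)CC2)n1`) gives only a limit, < 3 mL.min-1.g-1. Compound 3 (`FC(F)(F)c1nccc(N[C@H]2CC[C@@H](Nc3ccc4nnc(Br)n4n3)CC2)n1`) also gives only a limit, < 3 mL.min-1.g-1. Compound 3 therefore has no number of its own and sits at the limit of < 3 mL.min-1.g-1 in this assay, at which 2 of the 3 values shown sit.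

Compound 4 (`CSc1nnc2ccc(N[C@H]3CC[C@@H](Nc4ccnc(C(F)(F)F)n4)CC3)nn12`) carries methylsulfanyl in place of bromo on an aromatic carbon, methylsulfanyl in place of bromo on an aromatic carbon. Among the compounds with values here, the one measured step at this carbon is a step that the two limits leave unreadable from compound 2 to compound 3, so it offers no size to carry over. A modest step upward at most is therefore expected, and an at least 1.3-fold higher number from compound 3 to compound 4 (0.12 log units; that floor lies within the scatter) is the estimated step. In this assay the estimate for compound 4 is 4 mL.min-1.g-1, with an expected range of 2 mL.min-1.g-1 to 10 mL.min-1.g-1.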

Compound 4, intrinsic clearance in microsomes: 29 mL.min-1.g-1
Beside the measured number, compound 4's estimate is 7.3-fold (0.86 log units) below it, and the stated range ends below it.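

In this assay, this carbon, between two ring nitrogen atoms, gives its first readable steps: methylsulfanyl in place of bromo gives an at least 9.6-fold higher number from compound 3 to compound 4 (0.98 log units; beyond the scatter), and methylsulfanyl in place of hydrogen gives an at least 9.6-fold higher number from compound 2 to compound 4 (0.98 log units; beyond the scatter). Clearance at this position therefore depends on the group it carries, with both steps beyond the scatter. Both steps start from an assay limit, so each gives only a floor: the limit of < 3 mL.min-1.g-1 in this assay, at which 2 of the 4 values shown sit.

The step from hydrogen to bromo remains unreadable. Whether the rise goes with the sulfur atom stays open, since methoxy or an amine at this carbon is not among the compounds shown.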